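The source may report more compounds than this note shows. Statements on the series, on what has been measured and on what is new or still open speak of the compounds shown alone.

Measured compounds: compound 1 `COc1ccc(N(CC(=O)NCCC[Te]c2ccccc2)C(=O)CNC(=O)OC(C)(C)C)cc1` and compound 2 `COc1ccc(N(CC(=O)NCCC[Te]c2ccccc2)C(=O)c2ccccc2)cc1`. In an ADME assay on cells (Fibroblast, Homo sapiens) for cytotoxicity, read by MTT assay, with a stated time of 24 h (on this read-out lower numbers stand for stronger inhibition and higher numbers for weaker inhibition), compound 1 gives 25000 nM, and compound 2 gives 7500 nM.

Going by the values given here, compound 2 has the lowest number of the two; the only measured step, a 3.3-fold lower number from compound 1 to compound 2 (0.52 log units; beyond the scatter), is the one that leads to it. Compound 3 `COc1ccc(N(CC(=O)NCCC[Te]c2ccccc2)C(=O)/C=C/c2ccccc2)cc1` differs from compound 2 by 2-phenylethenyl in place of phenyl on a carbonyl carbon. Among the compounds with values here, no measured step tests a change of this kind; the step of a 3.3-fold lower number from compound 1 to compound 2 (0.52 log units; beyond the scatter) swaps a different group on a carbonyl carbon and so is only a loose guide. Compound 3 is expected to give about 5000 nM, between 1500 nM and 15000 nM. That expectation amounts to a 1.5-fold lower number from compound 2 to compound 3 (0.18 log units; within the scatter), a small step at most.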

Compound 3, half-maximal inhibitory concentration: 5000 nM
Compound 3: the middle estimate sits on the measured number at the digits printed; low and high end bracket the measured number.
By their numbers in this assay, from the lowest: compounds 3 and 2 (each within the scatter of the next); then compound 1.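

In this assay, the added double bond outside the ring makes no clear difference at this carbonyl carbon, with a 1.5-fold lower number from compound 2 to compound 3 (0.18 log units; within the scatter), so the benzoyl and (2-phenylethenyl)carbonyl groups cannot be told apart here. Against the ((tert-butoxycarbonyl)amino)methyl group, the new group gives a 5.0-fold lower number from compound 1 to compound 3 (0.70 log units; beyond the scatter), so both groups with an aromatic ring at this place give lower numbers than compound 1. Nothing available explains these numbers. The compounds shown leave open how a saturated 2-phenylethyl group, an aminomethyl group or a carboxylic acid would read at this carbonyl carbon.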